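The source may report more compounds than this note shows. Statements on the series, on what has been measured and on what is new or still open speak of the compounds shown alone.

Compound 1 `Cc1cccc(/C(CCN2CCN(c3ccccn3)CC2)=N/O)c1` gives 2.3 nM in a functional assay on HEK293 cells with D(4) dopamine receptor (Homo sapiens) as the target, read by FLIPR; on this read-out lower numbers stand for an effect already at smaller amounts and higher numbers for an effect only at larger amounts of compound. Compound 2 `CO/N=C(/CCN1CCN(c2ccccn2)CC1)c1cc(C)cc(C)c1` gives 74.7 nM in this assay. Compound 3 `CO/N=C(/CCN1CCC(c2ccccn2)CC1)c1ccc(Cl)cc1` gives > 10000 nM in this assay, which is a limit of the assay and not a number.

Compound 3 thus stands at the edge of what the assay reports, as the limit of > 10000 nM in this assay, at which 1 of the 3 values shown sits, shows. Compound 4 `CO/N=C(/CCN1CCC(c2cccc[n+]2[O-])CC1)c1ccc(Cl)cc1` differs from compound 3 in one place: a group of 7 heavy atoms (5 carbon, 1 nitrogen, 1 oxygen; one six-membered aromatic ring with 1 hetero atom) in place of a group of 6 heavy atoms (5 carbon, 1 nitrogen; one six-membered aromatic ring with 1 hetero atom), on a saturated ring carbon. Among the measured compounds shown here, no step between measured compounds covers a change of this kind, so the data give no measured size for it in this assay. Compound 4 is expected to stay near the limit, so the step that the limit leaves unreadable from compound 3 to compound 4 is estimated as no change beyond the scatter. For compound 4 the estimate is 15000 nM, with a range from 3000 nM to 60000 nM.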

Compound 4, half-maximal effective concentration: 46.4 nM
Compound 4: middle estimate off by 320-fold (2.51 log units), on the high side; measured number below the stated range.
By their numbers in this assay, from the lowest: compound 1; then compounds 4 and 2 (each within the scatter of the next). At a limit, above all of these: compound 3.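

On this saturated ring carbon, replacing pyridin-2-yl with the same ring carrying one added oxygen gives an at least 210-fold lower number from compound 3 to compound 4 (2.33 log units; beyond the scatter) in this assay. Among the compounds shown here, this is the first sign that so small a change at this place can turn a compound without a measured number into one with a clear number. Compound 3 stands at a limit: the limit of > 10000 nM in this assay, at which 1 of the 4 values shown sits.

What lies behind the step stays open. So does whether a methoxy group or an amine in place of the added oxygen would give a similar number.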